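Trading fluoro for cyano on a cytotoxic compound

A few compounds are considered here, and "the series" means these few. Any claim that something is new, unique, unknown or untested is made for them only; others in the source may bear on it.

Values measured in a functional assay on K562 cells (Homo sapiens) for cytotoxicity, read by MTT assay, with a stated time of 24 h (a lower number here means a stronger inhibitor, a higher number a weaker inhibitor), are as follows:
- compound 1 `CN1C/C(=C\c2ccc(C(C)(C)C)cc2)C(=O)/C(=C/c2ccccc2F)C1` gives 18200 nM in this test
- compound 2 `CN1C/C(=C\c2cccc([N+](=O)[O-])c2)C(=O)/C(=C/c2ccccc2F)C1` gives 3890 nM in this test
- compound 3 `COc1cc(/C=C2\CN(C)C/C(=C\c3ccc(F)cc3)C2=O)cc(OC)c1` gives 11300 nM in this test

Compound 3 at 11300 nM cannot be told apart from compound 1 at 18200 nM given the usual scatter, while compound 2 at 3890 nM has a clearly lower number. Compound 4 `COc1cc(/C=C2\CN(C)C/C(=C\c3ccc(C#N)cc3)C2=O)cc(OC)c1` keeps the core of compound 3 but has cyano in place of fluoro on an aromatic carbon para to a large group. Going by the values given here, no measured pair shows this swap alone, so only a small drop within the scatter is expected in this assay as a cautious guess. That weak lean rests on compound 2 at 3890 nM and its nitro group, on a different compound altogether. The estimated 1.4-fold lower number from compound 3 to compound 4 (0.15 log units; within the scatter) stays modest in size. For compound 4 the expected value is 8000 nM with an estimated range from 3000 nM to 20000 nM across repeat measurements.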

Compound 4, half-maximal inhibitory concentration: 4650 nM
Compound 4: the middle estimate sits 1.7-fold (0.24 log units) above what was measured; the measured number falls inside the stated range.
By their numbers in this assay, from the lowest: compounds 2 and 4 (each within the scatter of the next); then compounds 3 and 1 (each within the scatter of the next).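

Replacing 4-fluorophenyl with 4-cyanophenyl gives a 2.4-fold lower number from compound 3 to compound 4 (0.39 log units; beyond the scatter) in this assay. Going by these compounds alone, this is the first comparison here that differs in one place only, and it shows that the group at this position can change the result beyond the usual scatter. No measurement here accounts for the change.

On these data alone, only fluoro and cyano can be compared at this position, so it remains open how an amine or a carboxylic acid there would behave. As far as these compounds go, whether the same swap would have a similar effect on other compounds also remains open.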